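A few compounds are considered here, and "the series" means these few. Any claim that something is new, unique, unknown or untested is made for them only; others in the source may bear on it.

In a functional assay on KB-V1 cells (Homo sapiens) for cytotoxicity, read by MTT assay, with a stated time of 72 h (on this read-out lower numbers stand for stronger inhibition and higher numbers for weaker inhibition), compound 1 (`CC(SSC(C)C(=O)NCC(=O)O)C(=O)NCC(=O)O`) is reported as "not active" (no number reported) without a number. For the measured compounds named here, compound 2 (`CC(S)C(=O)N[C@@H](C)C(=O)O`) gives 490000 nM as the only number available, so no other value exists to rank it against. Compound 3 (`CC(S)C(=O)N[C@H](C(=O)O)C(C)C`) carries isopropyl in place of methyl on a saturated chain carbon bound to an amide-type nitrogen and a carbonyl carbon. Going by the values given here, no measured step guides this change, so in this assay the expected 1.6-fold lower number from compound 2 to compound 3 (0.21 log units; within the scatter) is small, within the scatter, and leans toward stronger inhibition. For compound 3 the estimated value is 300000 nM with an expected range from 100000 nM to 900000 nM as the likely span.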

Compound 3, half-maximal inhibitory concentration: 360000 nM
The estimate for compound 3 lay 1.2-fold (0.08 log units) below the measured number; low and high end bracket the measured number.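

In this assay, isopropyl in place of methyl on a saturated chain carbon bound to an amide-type nitrogen and a carbonyl carbon gives a 1.4-fold lower number from compound 2 to compound 3 (0.13 log units; within the scatter), so this position accepts isopropyl without a change beyond the scatter. For the compounds shown here, this is the only step that can be read, as compound 1 has no number. Nothing measured here offers an explanation for the result. The compounds shown leave open whether an amine, a carboxylic acid or a longer chain at this position would move the number beyond the scatter.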